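The source may report more compounds than this note shows. Statements on the series, on what has been measured and on what is new or still open speak of the compounds shown alone.

In a functional assay on MHCC97H cells (Homo sapiens) for antiproliferative activity, read by MTT assay, with a stated time of 48 h (on this read-out lower numbers stand for stronger inhibition and higher numbers for weaker inhibition), compound 2 (`COc1ccc2c(/C=C/C(=O)c3cc(OC)c(OC)c([N+](=O)[O-])c3)c[nH]c2c1`) gives 289 nM. This lies within the scatter of compound 1 (`COc1ccc2c(/C=C/C(=O)c3cc(N)c(OC)c(OC)c3)cn(C)c2c1`), which gives 198 nM, while compound 3 (`COc1cc(C(=O)/C=C/c2c[nH]c3ccccc23)cc([N+](=O)[O-])c1OC`) gives 830 nM, a clearly higher number. Still unmeasured is compound 4 (`COc1ccc2c(/C=C/C(=O)c3cc(OC)c(OC)c([N+](=O)[O-])c3)cn(C)c2c1`), which is compound 2 with a single change: methyl in place of hydrogen on an aromatic nitrogen, (methyl in place of hydrogen on an aromatic nitrogen). For the measured compounds named here, no measured pair isolates this change. Going by the values given here, the only single-place step available, a 2.9-fold higher number from compound 2 to compound 3 (0.46 log units; beyond the scatter), is hydrogen in place of methoxy on an aromatic carbon, so it says nothing direct about the nitrogen. Compound 2 also differs from compound 1 elsewhere, so that pair is not a clean comparison, yet compound 1, which carries this methyl, gives 198 nM, within the scatter of compound 2. On that basis, no step beyond the scatter is expected in this assay, and the estimated change is a 1.4-fold lower number from compound 2 to compound 4 (0.16 log units; within the scatter). Compound 4 is estimated at 200 nM, with an expected range of 70 nM to 600 nM.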

Compound 4, half-maximal inhibitory concentration: 562 nM
Compound 4: middle estimate off by 2.8-fold (0.45 log units), on the low side, within the range that was stated.
By their numbers in this assay, from the lowest: compounds 1, 2, 4 and 3 (each within the scatter of the next, the first and the last beyond it).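

In this assay, for the compounds shown here, the first clean reading of methyl in place of hydrogen on the aromatic nitrogen is a 1.9-fold higher number from compound 2 to compound 4 (0.29 log units; within the scatter), so at this position the swap gives no step that can be told apart from the scatter. Going by these compounds alone, compound 4 also gives the first clean reading of nitro in place of amino on an aromatic carbon, a 2.8-fold higher number from compound 1 to compound 4 (0.45 log units; beyond the scatter), a modest step that does lie beyond the scatter. Nothing measured here offers a reason for either step.

The compounds shown leave open how an ethyl group, a longer chain or a chain ending in an amine would behave on this nitrogen. They also leave open whether the swap between nitro and amino gives a similar step when the nitrogen carries hydrogen, as it does in compound 2.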